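The compounds below may be only part of what the source reports. "The series", "measured", "known", "first", "only" and "open" are said of these compounds alone.

Measured so far:
compound 1 `O=C(Nc1cccc(-c2nc3ccccc3s2)c1)c1cnccc1Cl` — 732 10^-6 cm/s
compound 2 `O=C(Nc1cccc(-c2nc3ccccc3s2)c1)c1cccnc1Cl` — 677 10^-6 cm/s

In an ADME assay for permeability, using PAMPA (on this read-out lower numbers stand for lower permeability and higher numbers for higher permeability), compound 1 stands at the top of the two numbers shown, but the single measured step, a 1.1-fold lower number from compound 1 to compound 2 (0.03 log units; within the scatter), is within the scatter, so the two compounds are not separated. Compound 3 `O=C(Nc1ccc(F)c(-c2nc3ccccc3s2)c1)c1cnccc1Cl` differs from compound 1 by fluoro in place of hydrogen on an aromatic carbon. Going by the values given here, no measured step introduces a fluoro; the one step available concerns a different part of the shared core and stayed within the scatter. The step of a 1.0-fold higher number from compound 1 to compound 3 (0.02 log units; within the scatter) is therefore expected to stay within the scatter, with no direction beyond it. Compound 3 is estimated at 760 10^-6 cm/s, range 450 10^-6 cm/s to 1250 10^-6 cm/s.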

Compound 3, apparent permeability: 21 10^-6 cm/s
Compound 3: the middle estimate sits 36-fold (1.56 log units) above what was measured, outside the stated range (below it).
By their numbers in this assay, from the lowest: compound 3; then compounds 2 and 1 (each within the scatter of the next).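

In this assay, fluoro in place of hydrogen on an aromatic carbon, ortho to a group of 9 heavy atoms and para to a large group, gives a 35-fold lower number from compound 1 to compound 3 (1.54 log units; beyond the scatter) on the core of compound 1. A single added heavy atom at this position is therefore enough for a large step, whereas the earlier change on the other side of the carbonyl, a 1.1-fold lower number from compound 1 to compound 2 (0.03 log units; within the scatter), stayed within the scatter. Nothing available here speaks to the reason for this drop.

Still open, as far as these compounds go, is whether the drop belongs to fluoro specifically or to any group at this position. A methyl, a methoxy or an amine in the same place would separate these two readings.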